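An aryl swap at the low end of stability

The source may hold more compounds than are shown below. What is called first, only, known or untested is meant among the compounds shown, and "the series" means these compounds.

In an ADME assay (liver) for metabolic stability, with Liver microsome (Canis lupus familiaris) as the target, read by LC-MS, using microsomes, with a stated time of 30 min, tested at 4 uM (on this read-out lower numbers stand for a less stable compound and higher numbers for a more stable compound), compound 3 (`COc1cccc(-c2nc3c(N4CCN(C)CC4)nc(C)nc3n2C2CCOCC2)c1`) gives 46% as the lowest of three numbers. Above it lie compound 1 (`Cc1nc(N2CCN(C)CC2)c2nc(-c3ccccc3Cl)n(CCN3CCCC3=O)c2n1`) at 60% and compound 2 (`Cc1nc(N2CCN(C)CC2)c2nc(-c3ccccc3Cl)n(C3CC3)c2n1`) at 98% on the same scale. Compound 4 (`CCc1ccccc1-c1nc2c(N3CCN(C)CC3)nc(C)nc2n1C1CCOCC1`) has 2-ethylphenyl in place of 3-methoxyphenyl on an aromatic carbon of the shared core (2-ethylphenyl in place of 3-methoxyphenyl on an aromatic carbon). Within the data shown here, the only measured step shows a number 38 percentage points higher from compound 1 to compound 2 (beyond the scatter) and it is large, yet it changes a group on an aromatic nitrogen and does not test this swap. Among the measured compounds shown here, with no measured step at this place, no step beyond the scatter is expected in this assay. The expected change is a number 4 percentage points higher from compound 3 to compound 4 (within the scatter) in size. Compound 4 is estimated at 50% with a range from 30% to 70% as the likely span.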

Compound 4, percent of the compound remaining: 74%
Compound 4: the middle estimate sits 24 percentage points below what was measured; measured number above the stated range.
By their numbers in this assay, from the lowest: compound 3; then compound 1; then compound 4; then compound 2.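

In this assay the aryl group on this aromatic carbon matters by itself: 2-ethylphenyl in place of 3-methoxyphenyl gives a number 28 percentage points higher from compound 3 to compound 4 (beyond the scatter), so stability responds to a change here as well as on the aromatic nitrogen. The data offer no measured explanation for this gain. The swap alters both the substituent and its numbered ring position, and these two changes remain unseparated. A 2-methoxyphenyl or 3-ethylphenyl group at this place would show which of them carries the difference.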